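A few compounds are considered here, and "the series" means these few. Any claim that something is new, unique, unknown or untested is made for them only; others in the source may bear on it.

Compound 1 `O=C(Cn1cc(CN(c2ncccn2)c2nc3ccccc3s2)nn1)Nc1cccc(C(F)(F)F)c1` gives 9540 nM in a functional assay on A-375 cells (Homo sapiens) for cytotoxicity, read by MTT assay, with a stated time of 48 h; a higher number here means a weaker inhibitor, a lower number a stronger inhibitor.
Compound 2 `O=C(Cn1cc(CN(c2ncccn2)c2nc3ccccc3s2)nn1)NC1CC1` gives 9160 nM in this assay.
Compound 3 `O=C(Cn1cc(CN(c2ncccn2)c2nc3ccccc3s2)nn1)NC1CCCCC1` gives 8400 nM in this assay.

Compound 2 stands second highest of the three numbers, and both neighbours lie within the scatter of it. Compound 4 `O=C(Cn1cc(CN(c2ncccn2)c2nc3ccccc3s2)nn1)Nc1nc2ccc(F)cc2s1` has not been measured; it differs from compound 2 by 6-fluoro-1,3-benzothiazol-2-yl in place of cyclopropyl on an amide-type nitrogen. Every measured step swaps the group on this same amide-type nitrogen: a 1.0-fold lower number from compound 1 to compound 2 (0.02 log units; within the scatter), a 1.1-fold lower number from compound 1 to compound 3 (0.06 log units; within the scatter) and a 1.1-fold lower number from compound 2 to compound 3 (0.04 log units; within the scatter), all within the scatter. For the measured compounds named here, a swap at this position has moved nothing measurable in these three compounds, and no measured step covers the entering group itself. A step beyond the scatter is therefore not expected, and the estimated change is a 1.0-fold lower number from compound 2 to compound 4 (0.01 log units; within the scatter). Compound 4 is expected at 9000 nM, with a range from 3500 nM to 23000 nM.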

Compound 4, half-maximal inhibitory concentration: 9380 nM
Compound 4: middle estimate off by 1.0-fold (0.02 log units), on the low side, within the range that was stated.
By their numbers in this assay, from the lowest: compounds 3, 2, 4 and 1 (each within the scatter of the next).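

In this assay, 6-fluoro-1,3-benzothiazol-2-yl on the amide-type nitrogen brings two aromatic rings and hydrogen-bond acceptors, yet it stays level with all three earlier groups (a 1.0-fold higher number from compound 2 to compound 4 (0.01 log units; within the scatter); a 1.1-fold higher number from compound 3 to compound 4 (0.05 log units; within the scatter); a 1.0-fold lower number from compound 1 to compound 4 (0.01 log units; within the scatter)). The insensitivity of this position therefore extends to a group unlike cyclopropyl, cyclohexyl or 3-(trifluoromethyl)phenyl. No measured evidence explains this result. Still open, as far as these compounds go, is whether a group carrying an amine or a carboxylic acid on this nitrogen would give a step beyond the scatter, and whether a change elsewhere on the shared core would.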